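The compounds below may be only part of what the source reports. "The series", "measured", "known", "first", "only" and "open" are said of these compounds alone.

Measured so far:
compound 1, `O=C(/C(=C\c1ccc([N+](=O)[O-])c(O)c1)SCc1ccc(Br)cc1)c1ccc(Br)cc1`, 10000 nM
compound 2, `O=C(/C(=C\c1cc(Br)c(O)c(Br)c1)SCc1ccc(Br)cc1)c1ccc(Br)cc1`, 1000 nM
compound 3, `O=C(/C(=C\c1ccc(Cl)cc1)Sc1ccc(Cl)cc1)c1ccc(Cl)cc1`, 1000 nM

In a functional assay on DU-145 cells (Homo sapiens) for inhibition, read by trypan blue exclusion, with a stated time of 96 h (a lower number here means a stronger inhibitor of growth, a higher number a weaker inhibitor of growth), compound 1 stands at the highest of the three numbers, the weakest growth inhibitor of the set; compound 2 and compound 3 share the same lower value. Within the data shown here, the one single-point step known is a 10-fold lower number from compound 1 to compound 2 (1.00 log units; beyond the scatter), which concerns the other end of the core. Compound 4, `O=C(/C(=C\c1ccc([N+](=O)[O-])c(O)c1)SCc1ccc(Br)cc1)C1CCNC1`, differs from compound 1 at the carbonyl carbon: pyrrolidin-3-yl in place of 4-bromophenyl on a carbonyl carbon. No measured step touches this position, so nothing shown bears directly on the change. With no guide, the expectation is a number near that of compound 1, leaning weaker, namely a 1.5-fold higher number from compound 1 to compound 4 (0.18 log units; within the scatter). Compound 4 is therefore estimated at 15000 nM, with a range from 3000 nM to 60000 nM.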

Compound 4, concentration for 50% growth inhibition: > 100000 nM
Compound 4: no number, only a limit; the forecaster's own chance of this, stated with the estimate: 30%; middle value at least 6.6-fold (0.82 log units) from the limit.
By their numbers in this assay, from the lowest: compounds 2 and 3 (each within the scatter of the next); then compound 1. At a limit, above all of these: compound 4.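

Among these compounds, the carbonyl position, untouched by the earlier steps, is not indifferent in this assay: pyrrolidin-3-yl in place of 4-bromophenyl on a carbonyl carbon gives an at least 10-fold higher number from compound 1 to compound 4 (1.00 log units; beyond the scatter). Compound 4 carries a limit and not a number: the limit of > 100000 nM in this assay, at which 1 of the 4 values shown sits. The full size of this step therefore cannot be read, only its minimum.

The compounds shown do not separate the loss of 4-bromophenyl from the entry of pyrrolidin-3-yl. Also open, going by these compounds, is how a plain phenyl or an open-chain amine on the carbonyl carbon would read on the core of compound 1.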